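One Halogen Less on the Anilino Ring

The compounds below may be only part of what the source reports. "The series", "measured", "known", "first", "only" and "open" are said of these compounds alone.

Measured compounds:
compound 1, `CN(C)C(=O)c1cc2cnc(Nc3ccc(NC(=O)C4(C(=O)Nc5cccc(Cl)c5)CC4)cc3)nc2n1C1CCCC1`, 39.3% in a functional assay on T47D cells (Homo sapiens) for inhibition, read by CCK-8 assay, with a stated time of 72 h, tested at 1 uM; a lower number here means less inhibition of growth, a higher number more inhibition of growth at the concentration tested
compound 2, `CN(C)C(=O)c1cc2cnc(Nc3ccc(NC(=O)C4(C(=O)Nc5ccc(Br)cc5)CC4)cc3)nc2n1C1CCCC1`, 21.1%

Going by the values given here, compound 2 stands at the lower of the two numbers in this assay; the only measured step, a number 18.2 percentage points lower from compound 1 to compound 2 (beyond the scatter), is the gap that separates the two. Compound 3, `CN(C)C(=O)c1cc2cnc(Nc3ccc(NC(=O)C4(C(=O)Nc5ccccc5)CC4)cc3)nc2n1C1CCCC1`, differs from compound 2 by hydrogen in place of bromo on an aromatic carbon. Among the compounds with values here, the one measured step exchanges one halogen-bearing phenyl for another and so bears on this change only indirectly; it shows that the anilide ring is not indifferent to what sits on it, but no measured step removes a halogen altogether. A step of uncertain direction is therefore expected, most likely within the scatter or modest. Compound 3 is estimated at 25% in this assay, with a range from 8% to 45%. That estimate is expected to mean a step of a number 3.9 percentage points higher from compound 2 to compound 3 (within the scatter).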

Compound 3, percent growth inhibition at one concentration: 52.8%
The estimate for compound 3 lay 27.8 percentage points below the measured number; measured number above the stated range.
By their numbers in this assay, from the lowest: compound 2; then compound 1; then compound 3.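

Removing the bromo gives a number 31.7 percentage points higher from compound 2 to compound 3 (beyond the scatter) in this assay, and removing the chloro gives a number 13.5 percentage points higher from compound 1 to compound 3 (beyond the scatter) in the same assay. The earlier step compared only one halogen-bearing ring with another, whereas these steps show that the plain phenyl stands above both, so a halogen at either of the two places shown goes with less growth inhibition here. No measured evidence accounts for this difference.

The 4-bromophenyl and 3-chlorophenyl rings differ in both the halogen and its place, so these compounds cannot separate the two effects. As far as these compounds go, it also remains open whether a fluoro, a methoxy or an amine on this ring would give a number nearer that of the plain phenyl or those of the halogen-bearing rings.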